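The source may hold more compounds than are shown below. What is called first, only, known or untested is meant among the compounds shown, and "the series" means these compounds.

Measured so far:
compound 1, `O=S(=O)(Nc1ccc(-c2nc3ccccc3o2)cc1)c1ccccc1Cl`: in an assay on isolated protein for inhibition of malate dehydrogenase, mitochondrial (Sus scrofa), with stated times of 45 min and 30 min (a higher number here means a weaker inhibitor, a lower number a stronger inhibitor), compound 1 gives > 63000 nM.
compound 2, `COc1ccccc1S(=O)(=O)Nc1ccc2oc(-c3ccccc3)nc2c1`: in this assay compound 2 gives > 63000 nM.

Both of these values are limits rather than numbers. Among the compounds with values here, compound 1 therefore stands at a limit, and the one further value shown is a limit too, so neither compound can be placed above or below the other (the limit of > 63000 nM in this assay, at which 2 of the 2 values shown sit). Compound 3, `O=S(=O)(Nc1ccc(-c2nc3ccccc3o2)cc1)c1ccc(O)cc1`, differs from compound 1 in one place: 4-hydroxyphenyl in place of 2-chlorophenyl on a sulfonyl sulfur. Within the data shown here, no step between measured compounds is available to guide this change, so its size can only be expected. Among the measured compounds shown here, with every value so far sitting at the limit (the limit of > 63000 nM in this assay, at which 2 of the 2 values shown sit), nothing points to a gain or a loss beyond the scatter, and the step expected here is a step that the limit leaves unreadable from compound 1 to compound 3. Compound 3 is therefore expected to give about 80000 nM, somewhere between 20000 nM and 300000 nM, and most probably it will again be reported only as a limit.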

Compound 3, half-maximal inhibitory concentration: > 63000 nM
Compound 3 was reported as a limit (the forecaster's own chance of this, stated with the estimate: 85%); the middle value does not contradict the limit.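

Compound 3, like compound 1, is reported only as a limit, so no step can be read between these two compounds: the limit of > 63000 nM in this assay, at which 3 of the 3 values shown sit.

The compounds shown leave open whether any change to the shared core or the group on the sulfonyl sulfur gives a real number in this assay.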